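The source may report more compounds than this note shows. Statements on the series, on what has been measured and on what is new or still open speak of the compounds shown alone.

Three compounds have been measured in a physicochemical assay for lipophilicity, using the shake flask method, measured as octanol-water partition, at pH 7.4; a higher number here means a more lipophilic compound, a lower number a more polar compound:

Compound 1 `CC(=O)N[C@@H]1CCC[C@H](C(=O)Nc2cc(-c3cnn4c3CC(C)(C)CC4)ccn2)C1` gives 3.1.
Compound 2 `CC(=O)N[C@@H]1CCC[C@H](C(=O)Nc2cc(-c3cnn4c3CC(C)(C)CC4)c(F)cn2)C1` gives 3.6.
Compound 3 `CC(=O)N[C@@H]1CCC[C@H](C(=O)Nc2cc(-c3cnn4c3CC(C)(C)C4)ccn2)C1` gives 2.8.

Compound 1 and compound 2 share the same core and differ in one place only: fluoro in place of hydrogen on an aromatic carbon. This single change gave a step of a number 0.50 log units higher from compound 1 to compound 2 (beyond the scatter) in this assay.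

Compound 3 carries a different core. How the two cores differ is not broken down here; the values alone show that compound 1 and compound 3 lie within the usual scatter of each other in this assay, while compound 2 sits higher than compound 3 by a margin beyond that scatter.

Compound 4 `CC(=O)N[C@@H]1CCC[C@H](C(=O)Nc2cc(-c3cnn4c3CC(C)(C)C4)c(F)cn2)C1` has not yet been measured. It stands to compound 3 exactly as compound 2 stands to compound 1: fluoro in place of hydrogen on an aromatic carbon. The surroundings of the change are the same in both pairs, so this is the same change made a second time, now on the core of compound 3.

Because compound 1 to compound 2 showed a number 0.50 log units higher from compound 1 to compound 2 (beyond the scatter), a step of similar size is expected from compound 3 to compound 4, namely a number 0.50 log units higher from compound 3 to compound 4 (beyond the scatter). On that basis compound 4 is estimated at 3.3 in this assay. Among the compounds with values here, the expected range for compound 4 runs from 2.9 to 3.7, allowing for the fact that only one earlier example of this change is available.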

Compound 4, distribution coefficient: 3.3
Compound 4: the middle estimate sits on the measured number at the digits printed; the range from low to high includes it.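

In this assay fluoro in place of hydrogen on an aromatic carbon gave a number 0.50 log units higher from compound 3 to compound 4 (beyond the scatter) and, on the other core, a number 0.50 log units higher from compound 1 to compound 2 (beyond the scatter) so across these two cores the change produced a step of the same size at the digits printed. This is a match between just two pairs of compounds, with the change made at the same place each time, so it shows that the step carried over once but does not establish a rule that would hold on a further core or at a different ring position. Nothing available here accounts for why the step has this size or why it matched on both cores.

The compounds shown hold only hydrogen and fluoro at this aromatic carbon, so it remains open whether chloro, methyl, methoxy or a nitrile at the same place would also give steps that match from one core to the other. Also open is whether the fluoro step would keep its size on a compound carrying an amine or a carboxylic acid, groups that do not appear among these four structures.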